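The compounds below may be only part of what the source reports. "The series", "measured", "known", "first", "only" and "open" are said of these compounds alone.

In a functional assay on HeLa cells (Homo sapiens) for inhibition, read by sulforhodamine B assay, with a stated time of 74 h (a lower number here means a stronger inhibitor, a higher number a weaker inhibitor), three compounds sharing one core have been measured. Compound 1 `Cc1ccc(S(=O)(=O)N2C(=O)COC23C=CC(=O)C=C3)cc1` gives 180 nM, compound 2 `CS(=O)(=O)N1C(=O)COC12C=CC(=O)C=C2` gives 7530 nM, and compound 3 `COc1ccc(S(=O)(=O)N2C(=O)COC23C=CC(=O)C=C3)cc1` gives 880 nM, the second highest of the three numbers. Compound 4 `O=C1C=CC2(C=C1)OCC(=O)N2S(=O)(=O)c1ccc(C(F)(F)F)cc1` has not yet been measured. It carries trifluoromethyl in place of methoxy on an aromatic carbon, para to a large group (trifluoromethyl in place of methoxy on an aromatic carbon). Among the compounds with values here, two measured steps bear on this change. The closer one, a 4.9-fold higher number from compound 1 to compound 3 (0.69 log units; beyond the scatter), is modest and puts methoxy in place of methyl at the same spot. The other, a 42-fold higher number from compound 1 to compound 2 (1.62 log units; beyond the scatter), is large, but it replaces the whole 4-methylphenyl with methyl, so it speaks less directly to this change. Within the data shown here, no measured compound carries trifluoromethyl, which leaves the direction uncertain. Methoxy gave the higher number in a 4.9-fold higher number from compound 1 to compound 3 (0.69 log units; beyond the scatter), so a modest move to a lower number is expected in this assay. The expected step is a 2.2-fold lower number from compound 3 to compound 4 (0.34 log units; beyond the scatter). For compound 4 the estimate is 400 nM, with an expected range of 130 nM to 1300 nM.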

Compound 4, half-maximal inhibitory concentration: 770 nM
Beside the measured number, compound 4's estimate is 1.9-fold (0.28 log units) below it; measured number inside the range.
By their numbers in this assay, from the lowest: compound 1; then compounds 4 and 3 (each within the scatter of the next); then compound 2.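

In this assay trifluoromethyl and methoxy on this aromatic carbon cannot be told apart: the change gives a 1.1-fold lower number from compound 3 to compound 4 (0.06 log units; within the scatter) and nothing more. Methyl now stands apart from both groups, with a 4.3-fold higher number from compound 1 to compound 4 (0.63 log units; beyond the scatter) alongside the earlier 4.9-fold higher number from compound 1 to compound 3 (0.69 log units; beyond the scatter) and so, among these three groups at this position, the lowest number belongs to methyl in compound 1. No measurement given here explains why methyl differs from the other two groups.

On these data alone, it remains open whether that low number is special to methyl or would also appear with an ethyl group, a chlorine atom or a plain hydrogen at this position. As far as these compounds go, how an amine or a carboxylic acid there would compare is equally open.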